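The compounds below may be only part of what the source reports. "The series", "measured", "known", "first", "only" and "open" are said of these compounds alone.

Measured compounds:
- compound 1, `CCNC(=O)c1cc(Oc2ccc(NC(=O)c3cc4cccnc4n(-c4ccccc4F)c3=O)cc2)ccn1`, in a functional assay on NCI-H460 cells (Homo sapiens) for antiproliferative activity, read by MTT assay, with a stated time of 72 h (on this read-out higher numbers stand for weaker inhibition and lower numbers for stronger inhibition), gives 1230 nM
- compound 2, `CCNC(=O)c1cc(Oc2ccc(NC(=O)c3cc4cccnc4n(-c4ccc(F)cc4)c3=O)cc2)ccn1`, in this assay gives 220 nM
- compound 3, `CCNC(=O)c1cc(Oc2ccc(NC(=O)c3cc4cccnc4n(-c4ccc(Cl)cc4)c3=O)cc2)ccn1`, in this assay gives "not determined" (no result reported); no result was reported for it

The three share a core and differ only in the aryl group on the aromatic nitrogen. Among the compounds with values here, the one measured step among them is a 5.6-fold lower number from compound 1 to compound 2 (0.75 log units; beyond the scatter), which moves the fluorine from one position of that phenyl ring to another and lowers the number by an amount beyond the scatter. As far as these compounds go, compound 3 carries a chlorine in the same position as the fluorine of compound 2, but where it stands in this assay is unknown, since no value was obtained.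

Compound 4, `CCNC(=O)c1cc(Oc2ccc(NC(=O)c3cc4cccnc4n(-c4ccc(OC)cc4)c3=O)cc2)ccn1`, has not yet been measured. It differs from compound 3 by methoxy in place of chloro on an aromatic carbon. Within the data shown here, no measured step bears directly on this exchange: the only step in hand, from compound 1 to compound 2, concerns the position of a substituent rather than its identity. With compound 3 lacking a number, the nearest reference for compound 4 is compound 2, whose substituent sits in the same place. The expectation is therefore a number in this assay close to that of compound 2, with no direction of change claimed beyond the scatter. On this basis compound 4 is estimated at 300 nM, with a range from 90 nM to 1500 nM.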

Compound 4, half-maximal inhibitory concentration: 1720 nM
Compound 4: the middle estimate sits 5.7-fold (0.76 log units) below what was measured, outside the stated range (above it).
By their numbers in this assay, from the lowest: compound 2; then compounds 1 and 4 (each within the scatter of the next).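

In this assay, what stands at this place on the phenyl ring matters as well as where it stands: methoxy in place of fluoro gives a 7.8-fold higher number from compound 2 to compound 4 (0.89 log units; beyond the scatter) and so the identity of the group, with its position held the same, also shifts the number by more than the scatter. The other new comparison, 4-methoxyphenyl in place of 2-fluorophenyl, gives a 1.4-fold higher number from compound 1 to compound 4 (0.15 log units; within the scatter) and so leaves these two compounds within the scatter of each other, while compound 2 alone is separated from both; the steps involving compound 3 cannot be read, since it has no number. Nothing measured alongside these compounds accounts for the change at this position.

The compounds shown leave open where chloro would fall in this assay and what a hydroxy group, a nitrile, an amine or a longer chain such as ethoxy would give at the same place. With only fluoro and methoxy read at this place, they also do not tell whether the value of compound 2 at 220 nM is particular to fluoro.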